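This account rests on a few compounds, and the source may have more. Where it says the series, first, only, none or still open, it means among the compounds named here.

Measured compounds:
Compound 1, `O=C(c1ccccc1)N(/N=N/c1ccc([N+](=O)[O-])cc1Br)c1ccc([N+](=O)[O-])cc1Br`: 1530 nM
Compound 2, `O=C(c1ccc(F)cc1)N(/N=N/c1ccc([N+](=O)[O-])cc1Br)c1ccc([N+](=O)[O-])cc1Br`: 580 nM
Compound 3, `O=C(c1ccccc1)N(/N=N/c1ccc([N+](=O)[O-])cc1Cl)c1ccc([N+](=O)[O-])cc1Cl`: 590 nM

All three were tested in a functional assay on HeLa cells (Homo sapiens) for cytotoxicity, read by MTT assay, with a stated time of 72 h; a higher number here means a weaker inhibitor, a lower number a stronger inhibitor. Compound 1 gives 1530 nM, and compound 2 gives 580 nM. The change between them is fluoro in place of hydrogen on an aromatic carbon, and it made a step of a 2.6-fold lower number from compound 1 to compound 2 (0.42 log units; beyond the scatter). Compound 3 gives 590 nM; its core differs from that of compound 1 in more than one place, and the difference between the two cores is not broken down here. The values of compound 2 and compound 3 lie within the scatter of each other.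

Compound 4, `O=C(c1ccccc1F)N(/N=N/c1ccc([N+](=O)[O-])cc1Cl)c1ccc([N+](=O)[O-])cc1Cl`, is not yet measured in this assay. It differs from compound 3 by fluoro in place of hydrogen on an aromatic carbon. Going by the values given here, this is the same kind of change as the one from compound 1 to compound 2, but the place is not the same: in compound 2 the fluoro sits para to a large group, whereas in compound 4 it sits ortho to a large group. Among the compounds with values here, only one such step has been measured, and it was made on a different core, so the expectation rests on a single example and on compound 3 because of 590 nM. Compound 4 is expected to move by a 1.5-fold lower number from compound 3 to compound 4 (0.17 log units; within the scatter), somewhat less than the earlier step. The estimate for compound 4 is 400 nM, with a range from 150 nM to 1200 nM.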

Compound 4, half-maximal inhibitory concentration: 2350 nM
Compound 4: the middle estimate sits 5.9-fold (0.77 log units) below what was measured; the whole stated range lies below it.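

In this assay, the change from phenyl to 2-fluorophenyl gave a 4.0-fold higher number from compound 3 to compound 4 (0.60 log units; beyond the scatter), a step in the opposite direction to the earlier one, and the two steps do not agree: the same change on two cores in this assay, a 2.6-fold lower number (0.42 log units; beyond the scatter) from compound 1 to compound 2 and a 4.0-fold higher number (0.60 log units; beyond the scatter) from compound 3 to compound 4, 11-fold (1.02 log units) apart, beyond the scatter of two such steps. In this series, then, fluoro in place of hydrogen on an aromatic carbon did not carry from the core of compound 1 to the core of compound 3 as a single, transferable effect, so the earlier step gave no reliable guide to the later one. What this does not show is the reason for the disagreement, as the two steps differ both in the core and in the place of the fluoro, which in compound 4 sits ortho to a large group, and one step on each core cannot separate these two differences.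

The compounds shown leave open whether the 2-fluorophenyl group would give a similar step on the core of compound 1, and whether the fluoro as placed in compound 2 would lower the number on the core of compound 3. They also leave open how an amine or a carboxylic acid on the phenyl ring would behave in this assay.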